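From methyl to hydroxymethyl at the lowest measured dose

The source may report more compounds than this note shows. Statements on the series, on what has been measured and on what is new or still open speak of the compounds shown alone.

Values measured in a functional assay on the whole organism with Mus musculus as the target, in the maximal electroshock model (a lower number here means that less compound is needed, a higher number that more compound is needed for the effect), are as follows
- compound 1 `CNC(=O)CNCc1ccc(OCc2cccc(Cl)c2)cc1` gives 48.6 mg/kg
- compound 2 `CN(CC(N)=O)Cc1ccc(OCc2cccc(Cl)c2)cc1` gives 70 mg/kg
- compound 3 `CNC(=O)[C@@H](C)NCc1ccc(OCc2ccccc2)cc1` gives 7 mg/kg

Compound 3 holds the lowest number of the three, and the numbers of compound 1 and compound 2 both lie beyond the scatter from it. The change under consideration leads to compound 4 `CNC(=O)[C@@H](CO)NCc1ccc(OCc2ccccc2)cc1` and is hydroxy in place of hydrogen on a saturated chain carbon, two bonds along the chain from an amine nitrogen and a carbonyl carbon; the same difference reads as methyl to hydroxymethyl. Within the data shown here, only one measured step links two compounds that differ in one place. It is a 1.4-fold higher number from compound 1 to compound 2 (0.16 log units; within the scatter) and lies within the scatter. Among the measured compounds shown here, that step involves no hydroxy group, so no measured step bears directly on this change, and its size cannot be carried over. Because compound 3 stands at 7 mg/kg a move to a higher number seems likelier than a move to a lower one, though the data do not settle this. The expected change is a 2.9-fold higher number from compound 3 to compound 4 (0.46 log units; beyond the scatter) with wide uncertainty. For compound 4 the estimated value is 20 mg/kg with an expected range from 7 mg/kg to 60 mg/kg in this assay.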

Compound 4, dose for half-maximal effect: 22.8 mg/kg
For compound 4 the middle estimate is 1.1-fold (0.06 log units) below the measured one; the range from low to high includes it.
By their numbers in this assay, from the lowest: compound 3; then compound 4; then compounds 1 and 2 (each within the scatter of the next).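

In this assay the change from methyl to hydroxymethyl gives a 3.3-fold higher number from compound 3 to compound 4 (0.51 log units; beyond the scatter) and so shows that this saturated chain carbon, two bonds along the chain from an amine nitrogen and a carbonyl carbon, responds to a single small change. Among these compounds, the only earlier step, a 1.4-fold higher number from compound 1 to compound 2 (0.16 log units; within the scatter), lay elsewhere in the molecule and stayed within the scatter, so this is the first single change here that moves the number beyond it. No measurement at hand explains why the added hydroxy group has this effect.

On these data alone, what an aminomethyl, a methoxymethyl or an ethyl group would do at this carbon stays open. As far as these compounds go, it is also open whether the hydroxy step would keep its size on the chlorine-bearing core of compound 1.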